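Imidazolyl in place of ethoxy on a fatty acid receptor agonist

A few compounds are considered here, and "the series" means these few. Any claim that something is new, unique, unknown or untested is made for them only; others in the source may bear on it.

Of the compounds shown here, three have been measured in a functional assay on HEK293 cells for agonist activity at Free fatty acid receptor 1 (Homo sapiens), read by fluorescence and calcium flux, with a stated time of 10 min; a higher number here means a larger maximal response, a lower number a smaller maximal response. Compound 1 `COc1ccc2c(c1)OC(COc1ccc(CCC(=O)O)c(F)c1)CC2` gives 58%, compound 2 `COCCOc1ccc2c(c1)OC(COc1ccc(CCC(=O)O)c(F)c1)CC2` gives 36%, and compound 3 `CCOC(CC(=O)O)c1ccc(OCC2COc3ccc(Cl)cc3O2)cc1` gives 46%. Compound 3 stands second of the three: its number lies within the scatter of compound 2, and compound 1 sits beyond the scatter above it. For the measured compounds named here, the only one-place step so far, a number 22 percentage points lower from compound 1 to compound 2 (beyond the scatter), concerns a change at a different place than the one now considered.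

Compound 4 `Cn1cncc1C(CC(=O)O)c1ccc(OCC2COc3ccc(Cl)cc3O2)cc1` differs from compound 3 in one place: 1-methyl-1H-imidazol-5-yl in place of ethoxy on a saturated chain carbon bound to an aromatic carbon and a saturated chain carbon. Going by the values given here, no measured step touches this position, so nothing in the data bears directly on it; the one known step shows that a change on a chain carbon can move the maximal response by a modest amount. The step to compound 4 in this assay is therefore expected to stay within the scatter, with no change at the digits printed from compound 3 to compound 4 (within the scatter) as the estimate. Compound 4 is expected to give 46%, between 25% and 65%.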

Compound 4, largest response reached (Emax), in percent of the reference or control that the assay uses: 62%
Estimate against measurement, compound 4: 16 percentage points below; low and high end bracket the measured number.
By their numbers in this assay, from the lowest: compounds 2 and 3 (each within the scatter of the next); then compounds 1 and 4 (each within the scatter of the next).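

At the saturated chain carbon bound to an aromatic carbon and a saturated chain carbon, replacing ethoxy with 1-methyl-1H-imidazol-5-yl gives, in this assay, a number 16 percentage points higher from compound 3 to compound 4 (beyond the scatter) and so moves the maximal response upward by a modest amount. Until now, this position was represented only by ethoxy; the new pair shows that it accepts a larger group carrying a five-membered aromatic ring with 2 hetero atoms, and that the response there is sensitive to the group it carries. No available evidence accounts for the rise. 

As far as these compounds go, whether the imidazole ring itself matters remains open, since a phenyl ring, a dimethylamino group or a pyridine ring on the same carbon would be needed to tell. Also open, from the compounds shown here alone, is how a hydroxyl group or a longer alkoxy chain would compare with ethoxy at this position.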